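The source may report more compounds than this note shows. Statements on the series, on what has been measured and on what is new or still open speak of the compounds shown alone.

Measured compounds:
Compound 1, `NC1(CCn2ncc(=O)[nH]c2=O)OC(=O)C(OCc2ccccc2)=C1OCc1ccccc1`: > 100000 nM
Compound 2, `Nc1ccn(C[C@H](O)[C@H]2OC(=O)C(OCc3ccccc3)=C2OCc2ccccc2)c(=O)n1`: > 100000 nM
Compound 3, `O=C1O/C(=C\Cn2c(=O)[nH]c(=O)[nH]c2=O)C(OCc2ccccc2)=C1OCc1ccccc1`: 37900 nM

All three were tested in a functional assay on MIA PaCa-2 cells (Homo sapiens) for inhibition, read by MTT assay, with a stated time of 72 h; on this read-out lower numbers stand for stronger inhibition and higher numbers for weaker inhibition. For compound 1 the recorded value of > 100000 nM is a limit of the assay and not a number. Compound 2 also returns only a limit, > 100000 nM. Within the data shown here, compound 3 is the one compound of the three with a measured number, giving 37900 nM. Compound 1 thus stands at the limit of > 100000 nM in this assay, at which 2 of the 3 values shown sit, and nothing more can be said of where it lies beyond that.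

Compound 4, `Cc1cn(CCC2(N)OC(=O)C(OCc3ccccc3)=C2OCc2ccccc2)c(=O)[nH]c1=O`, differs from compound 1 in one place: a group of 9 heavy atoms (5 carbon, 2 nitrogen, 2 oxygen; one six-membered aromatic ring with 2 hetero atoms) in place of a group of 8 heavy atoms (3 carbon, 3 nitrogen, 2 oxygen; one six-membered aromatic ring with 3 hetero atoms), on a saturated chain carbon, two bonds along the chain from a saturated ring carbon. Among the measured compounds shown here, no step between two measured compounds is known here, so the size of this change can only be expected, not read off from data. Since compound 1 sits at a limit, the expectation for compound 4 is a step of none beyond the scatter, a step that the limit leaves unreadable from compound 1 to compound 4. Compound 4 is expected to give about 120000 nM in this assay, with a range from 40000 nM to 400000 nM, and most likely again only a limit will be reported.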

Compound 4, half-maximal inhibitory concentration: > 100000 nM
Compound 4: a limit, no number; the forecaster's own chance of this, stated with the estimate: 70%; the middle value does not contradict the limit.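

Compound 1 and compound 4 both return only a limit of the assay in this assay, not a number, so no step can be read between them. The compounds shown leave open whether exchanging the one ring group for the other changes inhibition at all, and most of the series stays at one value: the limit of > 100000 nM in this assay, at which 3 of the 4 values shown sit.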